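The source may hold more compounds than are shown below. What is called first, only, known or untested is meant among the compounds shown, and "the series" means these compounds.

Compound 1 `O=C1COc2ccc(-c3cnc(Cl)c(NS(=O)(=O)c4ccc(F)cc4)c3)cc2N1c1ccc(F)cc1` carries a 4-fluorophenyl on an amide-type nitrogen in a ring. In a functional assay on A-375 cells (Homo sapiens) for antiproliferative activity, read by MTT assay, with a stated time of 72 h (on this read-out higher numbers stand for weaker inhibition and lower numbers for stronger inhibition), compound 1 reaches only a limit of the assay, > 40000 nM. Compound 2 `O=C1COc2ccc(-c3cnc(Cl)c(NS(=O)(=O)c4ccc(F)cc4)c3)cc2N1` differs from compound 1 by hydrogen in place of 4-fluorophenyl on an amide-type nitrogen in a ring. In this assay compound 2 likewise reaches only a limit, > 40000 nM. The step that the two limits leave unreadable from compound 1 to compound 2 cannot be sized, as every value shown sits at the limit of > 40000 nM in this assay, at which 3 of the 3 values shown sit. Compound 3 `O=C1COc2ccc(-c3cnc4ccccc4c3)cc2N1c1ccc(F)cc1` has another core, and the difference between the two cores is not broken down here. In this assay compound 3 also gives only a limit, > 40000 nM. Compound 4 `O=C1COc2ccc(-c3cnc4ccccc4c3)cc2N1` arises from compound 3 by the same change, (hydrogen in place of 4-fluorophenyl on an amide-type nitrogen in a ring). The expected step that the limit leaves unreadable from compound 3 to compound 4 rests on compound 1 and compound 2, whose step that the two limits leave unreadable from compound 1 to compound 2 is not readable. Compound 4 is expected at 50000 nM, most likely again a limit.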

Compound 4, half-maximal inhibitory concentration: > 40000 nM
Compound 4: only a limit was reported (the forecaster's own chance of this, stated with the estimate: 85%); the middle value is on the limit's open side.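

No step can be sized from compound 3 to compound 4, as both compounds give only a limit: the limit of > 40000 nM in this assay, at which 4 of the 4 values shown sit.

The compounds shown leave open whether hydrogen in place of 4-fluorophenyl changes inhibition at all in this assay.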